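Shortening the para-side arm from compound 3 to compound 4

A few compounds are considered here, and "the series" means these few. Any claim that something is new, unique, unknown or untested is made for them only; others in the source may bear on it.

Compound 3 `CN(C)C(=O)c1cc2cnc(Nc3ccc(C(=O)NCCCCCCN=C=S)cc3)nc2n1C1CCCC1` gives 49.4% in a functional assay on NCI-H1299 cells (Homo sapiens) for inhibition, read by CCK-8 assay, with a stated time of 72 h, tested at 1 uM (on this read-out higher numbers stand for a stronger effect at the one concentration tested and lower numbers for a weaker effect), and stands lowest of the three measured numbers. Compound 1 `CN(C)C(=O)c1cc2cnc(Nc3ccc(S(=O)(=O)NCCCCCN=C=S)cc3)nc2n1C1CCCC1` with 52.1% lies within the scatter of compound 3, whereas compound 2 `CN(C)C(=O)c1cc2cnc(Nc3ccc(C(=O)NCCCN=C=S)cc3)nc2n1C1CCCC1` with 65.1% sits above it by a step beyond the scatter. Compound 4 `CN(C)C(=O)c1cc2cnc(Nc3ccc(NC(=O)CCCCN=C=S)cc3)nc2n1C1CCCC1` is not yet measured. Its change from compound 3 is a group of 10 heavy atoms (6 carbon, 2 nitrogen, 1 oxygen, 1 sulfur; no ring) in place of a group of 12 heavy atoms (8 carbon, 2 nitrogen, 1 oxygen, 1 sulfur; no ring), on an aromatic carbon. The step that bears most on this is a number 15.7 percentage points lower from compound 2 to compound 3 (beyond the scatter), where a longer chain between the amide-type nitrogen and the isothiocyanate went with a lower number. The step of a number 2.7 percentage points lower from compound 1 to compound 3 (within the scatter) adds that a different arm of the same atom count left the number within the scatter. Within the data shown here, compound 4 carries a shorter arm than compound 3, so a modest rise is expected, though the arm in compound 4 is joined to the ring in a way that has no measured counterpart here, which widens the range. Compound 4 is therefore expected to give 57% in this assay, with a range from 44% to 69%. The expected step is a number 7.6 percentage points higher from compound 3 to compound 4 (within the scatter).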

Compound 4, a percentage reported as inhibition, at one concentration (the size of the read-out at that concentration, not a potency): 58.6%
Compound 4: the middle estimate sits 1.6 percentage points below what was measured; measured number inside the range.
By their numbers in this assay, from the lowest: compounds 3, 1, 4 and 2 (each within the scatter of the next, the first and the last beyond it).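

At this aromatic carbon, the group of 10 heavy atoms carries the same counts of hydrogen-bond donors and acceptors as the group it replaces, and this assay shows a number 9.2 percentage points higher from compound 3 to compound 4 (within the scatter). Against the other two arms it shows a number 6.5 percentage points lower from compound 2 to compound 4 (within the scatter) and a number 6.5 percentage points higher from compound 1 to compound 4 (within the scatter), so compound 4 cannot be told apart from any earlier compound, although compound 2 and compound 3 stand apart from each other by a step beyond the scatter. No measurement at hand explains these numbers.

On these data alone, how the number follows chain length on the arm of compound 4 stays open, for a longer chain as for a shorter one. Also open, as far as these compounds go, is whether the isothiocyanate matters at the end of this arm, as an amine or a carboxylic acid in that place would test.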